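Amide aryl variation on a flavonol scaffold

This account rests on a few compounds, and the source may have more. Where it says the series, first, only, none or still open, it means among the compounds named here.

Three amides sharing one core have been measured in a functional assay on GTL 16 cells for antiproliferative activity against GTL 16 cell line (Homo sapiens), read by CCK-8 assay, with a stated time of 72 h; on this read-out higher numbers stand for weaker inhibition and lower numbers for stronger inhibition. Compound 1 `O=C(Nc1cccc(-c2oc3cc(-c4ccc(F)cc4)ccc3c(=O)c2O)c1)c1ccc(Br)cc1` gives 25400 nM there, compound 2 `CCc1ccc(C(=O)Nc2cccc(-c3oc4cc(-c5ccc(F)cc5)ccc4c(=O)c3O)c2)cc1` gives 24600 nM, and compound 3 `Cc1cc(C(=O)Nc2cccc(-c3oc4cc(-c5ccc(F)cc5)ccc4c(=O)c3O)c2)ccc1F` gives 12100 nM. Between compound 1 and compound 2 the step of a 1.0-fold lower number from compound 1 to compound 2 (0.01 log units; within the scatter) shows nothing beyond the scatter, whereas the steps of a 2.1-fold lower number from compound 1 to compound 3 (0.32 log units; beyond the scatter) and a 2.0-fold lower number from compound 2 to compound 3 (0.31 log units; beyond the scatter) are modest but real, so compound 3 stands lowest of the three.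

Compound 4 `N#Cc1ccc(C(=O)Nc2cccc(-c3oc4cc(-c5ccc(F)cc5)ccc4c(=O)c3O)c2)cc1` differs from compound 3 by 4-cyanophenyl in place of 4-fluoro-3-methylphenyl on a carbonyl carbon. Going by the values given here, no measured step involves a 4-cyanophenyl group, so the two informative steps, from compound 1 and from compound 2 to compound 3, only show that exchanging the aryl on the carbonyl carbon can move this assay by a modest amount. As compound 3 is the lowest point, the author expects compound 4 to return toward the level of compound 1 and compound 2, a step of a 1.5-fold higher number from compound 3 to compound 4 (0.17 log units; within the scatter), possibly within the scatter. Compound 4 is therefore estimated at 18000 nM in this assay, with a range from 8000 nM to 40000 nM.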

Compound 4, half-maximal inhibitory concentration: 31800 nM
Estimate against measurement, compound 4: 1.8-fold (0.25 log units) below, and the stated range covers the measured number.
By their numbers in this assay, from the lowest: compound 3; then compounds 2, 1 and 4 (each within the scatter of the next).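

In this assay the nitrile-bearing 4-cyanophenyl group gives up the advantage of the 4-fluoro-3-methylphenyl group (a 2.6-fold higher number from compound 3 to compound 4 (0.42 log units; beyond the scatter)), but it stays within the scatter of the bromo compound (a 1.3-fold higher number from compound 1 to compound 4 (0.10 log units; within the scatter)) and of the ethyl compound (a 1.3-fold higher number from compound 2 to compound 4 (0.11 log units; within the scatter)). Cyano thus joins bromo and ethyl as a third group on that aromatic carbon with no step beyond the scatter among them, and compound 3 alone stands apart from the other three amides. Nothing available here accounts for this difference.

The compounds shown leave open whether the lower number of compound 3 goes with the fluorine, with the methyl or only with the two together. They also leave open how an amine or a carboxylic acid on that aryl ring would read.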